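This account rests on a few compounds, and the source may have more. Where it says the series, first, only, none or still open, it means among the compounds named here.

Of the compounds shown here, three of a shared core have already been measured in an in vitro assay on 293-EBNA cells for binding affinity to corticotropin-releasing factor receptor 1 (Homo sapiens); a higher number here means a weaker inhibitor, a lower number a stronger inhibitor. Compound 1 `CCCC(CCC)Nc1nc(C)nc2c1nnn2-c1ccc(Br)cc1Br` gives 0.8 nM in this assay, and compound 3 `CCCCN(CC)c1nc(C)nc2c1nnn2-c1c(Br)cc(OC)cc1OC` gives 3 nM. Compound 2 `Cc1nc(N2CCCC2)c2nnn(-c3ccc(C(C)C)cc3Br)c2n1` stands apart: in this assay compound 2 gives 194 nM, the highest of the three numbers, so it is the weakest binder of the set, with both gaps to compound 3 and to compound 1 well beyond the scatter of repeated measurements.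

The next compound, compound 4 `COCCCNc1nc(C)nc2c1nnn2-c1ccc(C(C)C)cc1Br`, keeps the aromatic substituent of compound 2 and changes only the amino group on the core: (3-methoxypropyl)amino in place of pyrrolidin-1-yl on an aromatic carbon. Compound 1 and compound 3, the two compounds whose amino groups are open chains rather than a ring, both give low numbers in this assay, which points toward a lower number for compound 4 as well. The step from compound 2 to compound 4 is therefore expected to be a clear gain in binding, of the size a 19-fold lower number from compound 2 to compound 4 (1.29 log units; beyond the scatter), beyond the scatter. On that basis compound 4 is estimated to give about 10 nM in this assay, most likely somewhere between 2 nM and 50 nM.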

Compound 4, inhibition constant: 291 nM
For compound 4 the middle estimate is 29-fold (1.46 log units) below the measured one, and the stated range ends below it.
By their numbers in this assay, from the lowest: compound 1; then compound 3; then compounds 2 and 4 (each within the scatter of the next).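

In this assay, for the compounds shown here, compound 2 and compound 4 are the only pair here that differs in this one place, and the change gives a 1.5-fold higher number from compound 2 to compound 4 (0.18 log units; within the scatter) with the same aromatic substituent kept. At this aromatic carbon, then, the two groups cannot be told apart, even though (3-methoxypropyl)amino has no ring and adds an oxygen and a hydrogen-bond donor. An open chain alone therefore does not bring a low number in this pair, the low numbers of compound 1 and compound 3 cannot be credited to their open chains, as those two compounds also carry different substituents on the aromatic ring, and nothing measured here explains why the two groups in this pair read alike.

Still open, on these data alone, is whether the branched or dialkylated amino groups of compound 1 and compound 3 would give low numbers when paired with the aromatic substituent of compound 2. As far as these compounds go, it is equally open how this position would respond to a piperidine ring, a morpholine ring, or a chain ending in a hydroxyl group or a carboxylic acid.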